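Swapping the anilino substituent on a tricyclic quinone core

The compounds below may be only part of what the source reports. "The series", "measured", "known", "first", "only" and "open" are said of these compounds alone.

Measured so far in a functional assay on MGC-803 cells (Homo sapiens) for inhibition, read by sulforhodamine B assay; on this read-out higher numbers stand for weaker inhibition and lower numbers for stronger inhibition:
compound 1 `COc1ccccc1NC1=CC(=O)c2c(nc3n2[C@H]2OC[C@@H](O)[C@H]2OC3)C1=O` — 1670 nM
compound 2 `O=C1C=C(Nc2ccc(C(F)(F)F)cc2)C(=O)c2c1nc1n2[C@H]2OC[C@@H](O)[C@H]2OC1` — 2820 nM
compound 3 `CCOc1ccccc1NC1=CC(=O)c2nc3n(c2C1=O)[C@H]1OC[C@@H](O)[C@H]1OC3` — 2450 nM

Compound 1 gives the lowest of the three numbers, but its nearest neighbour compound 3 sits within the scatter of it, as does compound 2, so no ordering among the three can be claimed. Going by the values given here, the one single-point step among the measured compounds, a 1.2-fold lower number from compound 2 to compound 3 (0.06 log units; within the scatter), is also within the scatter.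

The unmeasured compound 4 `O=C1C(Nc2ccc(Br)cc2)=CC(=O)c2c1nc1n2[C@H]2OC[C@@H](O)[C@H]2OC1` differs from compound 1 by 4-bromophenyl in place of 2-methoxyphenyl on an amine nitrogen. Among the compounds with values here, no measured step covers this exact exchange; the only comparison that touches an aryl group on the amine nitrogen, the step from compound 2 to compound 3, was flat. Compound 2 carries a 4-(trifluoromethyl)phenyl group and sits where it does, while compound 4 also carries a group substituted in the 4-position, so a number in the same region as compounds 2 and 3 seems likely, but no step beyond the scatter is expected.

Compound 4 is therefore expected to give about 2500 nM, between 1000 nM and 6000 nM. The expected step is a 1.5-fold higher number from compound 1 to compound 4 (0.18 log units; within the scatter).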

Compound 4, half-maximal inhibitory concentration: 2020 nM
The estimate for compound 4 lay 1.2-fold (0.09 log units) above the measured number; measured number inside the range.
By their numbers in this assay, from the lowest: compounds 1, 4, 3 and 2 (each within the scatter of the next).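

In this assay, the new exchange gives a 1.2-fold higher number from compound 1 to compound 4 (0.08 log units; within the scatter), so a second change of the aryl group on the amine nitrogen leaves the number within the scatter, as did a 1.2-fold lower number from compound 2 to compound 3 (0.06 log units; within the scatter). This step also takes the comparison further: 4-bromophenyl has no hydrogen-bond acceptor where 2-methoxyphenyl has one, and the substituent sits at a different ring position, yet neither difference comes with a step beyond the scatter. No supporting data bear on this result.

All four compounds carry a singly substituted phenyl ring on this nitrogen and share the same core. As far as these compounds go, it remains open whether a pyridine ring, a phenyl ring bearing a carboxylic acid, or a plain alkyl chain on the nitrogen would produce a step beyond the scatter.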